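This account rests on a few compounds, and the source may have more. Where it says the series, first, only, none or still open, it means among the compounds named here.

Of the compounds shown here, three sharing one core have been measured, and a fourth awaits its number. Compound 1 `CCn1nc(-c2ccnc(Nc3ccc(S(N)(=O)=O)cc3)n2)c2ccccc21` carries a sulfamoyl group and an ethyl chain; compound 2 `CCn1nc(-c2ccnc(Nc3ccc(O)cc3)n2)c2ccccc21` keeps the ethyl chain but has a hydroxy group in place of the sulfamoyl; compound 3 `CCCn1nc(-c2ccnc(Nc3ccc(O)cc3)n2)c2ccccc21` is compound 2 with a propyl chain instead.

In a functional assay on HCT-116 cells (Homo sapiens) for antiproliferative activity, read by MTT assay, with a stated time of 72 h (on this read-out lower numbers stand for stronger inhibition of growth and higher numbers for weaker inhibition of growth), compound 1 gives 2050 nM. Compound 2 gives 5290 nM, and compound 3 gives 5450 nM.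

The change from compound 2 to compound 1, (sulfamoyl in place of hydroxy on an aromatic carbon), gives a 2.6-fold lower number from compound 2 to compound 1 (0.41 log units; beyond the scatter). The cores of compound 2 and compound 3 differ by methyl in place of hydrogen on a saturated chain carbon, two bonds along the chain from an aromatic nitrogen, and that change gives a 1.0-fold higher number from compound 2 to compound 3 (0.01 log units; within the scatter), so the two cores behave alike as far as these numbers show.

Compound 4 `CCCn1nc(-c2ccnc(Nc3ccc(S(N)(=O)=O)cc3)n2)c2ccccc21` is not yet measured. Among the measured compounds shown here, it differs from compound 3 by sulfamoyl in place of hydroxy on an aromatic carbon, which is the same change as the one from compound 2 to compound 1, made on the propyl core rather than the ethyl one.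

Compound 4 is expected to show a step of about a 2.6-fold lower number from compound 3 to compound 4 (0.41 log units; beyond the scatter), close to a 2.6-fold lower number from compound 2 to compound 1 (0.41 log units; beyond the scatter), because a 1.0-fold higher number from compound 2 to compound 3 (0.01 log units; within the scatter) shows the two cores giving much the same number with the hydroxy group in place. On that basis compound 4 is estimated at 2100 nM, with a likely range from 1000 nM to 4500 nM in this assay.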

Compound 4, concentration for 50% growth inhibition: 6740 nM
For compound 4 the middle estimate is 3.2-fold (0.51 log units) below the measured one; the measured number lies above the stated range.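

Swapping hydroxy for sulfamoyl on the propyl core gives a 1.2-fold higher number from compound 3 to compound 4 (0.09 log units; within the scatter) in this assay, so the drop in the number seen on the ethyl core does not carry over to the propyl core: the same change on two cores in this assay, a 2.6-fold lower number (0.41 log units; beyond the scatter) from compound 2 to compound 1 and a 1.2-fold higher number (0.09 log units; within the scatter) from compound 3 to compound 4, 3.2-fold (0.50 log units) apart, beyond the scatter of two such steps

The chain shows the same thing from the other side, since going from ethyl to propyl with sulfamoyl in place gives a 3.3-fold higher number from compound 1 to compound 4 (0.52 log units; beyond the scatter), while the same change with hydroxy in place stayed within the scatter: the same change on two cores in this assay, a 1.0-fold higher number (0.01 log units; within the scatter) from compound 2 to compound 3 and a 3.3-fold higher number (0.52 log units; beyond the scatter) from compound 1 to compound 4, 3.2-fold (0.50 log units) apart, beyond the scatter of two such steps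

In these four compounds, then, the effect of each change depends on what sits at the other place, and a step measured on one core cannot simply be transferred to the other; this does not show why the two places are linked, nor whether the link extends beyond this one pair of groups, this one pair of chains and this one assay.

Going by these compounds, it remains open whether a methyl or butyl chain in place of the ethyl or propyl chain would side with compound 1 or with compound 4. Also open, on these data alone, is whether an amine or a carboxylic acid in place of the hydroxy group would depend on the chain in the same way.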